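Adding chloro to compound 2

A few compounds are considered here, and "the series" means these few. Any claim that something is new, unique, unknown or untested is made for them only; others in the source may bear on it.

Values measured in a functional assay on CCRF-CEM cells (Homo sapiens) for inhibition, read by cell counting, with a stated time of 72 h; a higher number here means a weaker inhibitor, a lower number a stronger inhibitor
compound 1 `CCN(CC)CN1C(=O)/C(=N/NC(N)=S)c2cc(Cl)ccc21` gives 71000 nM
compound 2 `CCN(CC)CN1C(=O)/C(=N/NC(=S)Nc2ccc(OC)cc2)c2ccccc21` gives 1900 nM

Compound 2 stands lowest of the two measured compounds at 1900 nM with a gap to the higher number of compound 1 that lies beyond the scatter. Compound 3 `CCN(CC)CN1C(=O)/C(=N/NC(=S)Nc2ccc(OC)cc2)c2cc(Cl)ccc21` has chloro in place of hydrogen on an aromatic carbon of a six-membered aromatic ring of carbon only, meta to a fused ring and para to a fused ring (chloro in place of hydrogen on an aromatic carbon). Going by the values given here, compound 1 also carries chloro but differs from compound 2 elsewhere too, so no measured pair isolates this change. A small move toward a lower number is expected in this assay and may not exceed the scatter (estimated a 1.3-fold lower number from compound 2 to compound 3 (0.10 log units; within the scatter)). The expected value for compound 3 is 1500 nM (estimated range 450 nM to 5000 nM).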

Compound 3, half-maximal inhibitory concentration: 6900 nM
For compound 3 the middle estimate is 4.6-fold (0.66 log units) below the measured one; measured number above the stated range.
By their numbers in this assay, from the lowest: compound 2; then compound 3; then compound 1.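

In this assay, chloro in place of hydrogen on an aromatic carbon of the six-membered aromatic ring of carbon only gives a weaker inhibitor in the presence of the 4-methoxyphenyl group (a 3.6-fold higher number from compound 2 to compound 3 (0.56 log units; beyond the scatter)). With chloro held constant, 4-methoxyphenyl in place of hydrogen on an amide-type nitrogen gives a stronger inhibitor (a 10-fold lower number from compound 1 to compound 3 (1.01 log units; beyond the scatter)), so the two changes have now each been isolated, and the larger step belongs to the 4-methoxyphenyl group. No available evidence accounts for the direction or size of either step.

On these data alone, each change is seen on one background only, so the chloro step on the compound lacking 4-methoxyphenyl remains unknown. Also open, as far as these compounds go, is how fluoro or bromo at this position, or a plain phenyl or longer alkyl chain on the nitrogen, would compare.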